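Swapping one aromatic group on compound 3

The source may report more compounds than this note shows. Statements on the series, on what has been measured and on what is new or still open speak of the compounds shown alone.

Compound 1 `CC1CN(c2nc(-c3ccc4ccccc4c3)nn2-c2ccccc2)C2(C=CC(=O)C=C2)O1`: 130 nM
Compound 2 `CC1OC2(C=CC(=O)C=C2)N(c2nc(-c3cccc4ccccc34)nn2-c2ccccc2)C1=O`: 100 nM
Compound 3 `O=C1C=CC2(C=C1)OCC(=O)N2c1nc(-c2ccc3c(c2)OCCO3)nn1-c1ccccc1`: 100 nM

In a functional assay on MDA-MB-231 cells (Homo sapiens) for antiproliferative activity, with a stated time of 5 days (a higher number here means a weaker inhibitor, a lower number a stronger inhibitor), compound 3 gives 100 nM, level with compound 2 and within the usual scatter of compound 1, so these three values do not separate.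

Compound 4 `O=C1C=CC2(C=C1)OCC(=O)N2c1nc(-c2ccc(F)c3ccccc23)nn1-c1ccccc1` keeps the core of compound 3 and changes one group: 4-fluoronaphthalen-1-yl in place of 2,3-dihydro-1,4-benzodioxin-6-yl on an aromatic carbon. Among the compounds with values here, no two measured compounds differ in one place alone, so there is no direct guide to this change. The nearest hint is indirect: with two six-membered aromatic rings of carbon only at that carbon, compound 1 gives 130 nM and compound 2 gives 100 nM. Neither value stands apart from compound 3, so no change beyond the scatter is expected in either direction. The expected no change at the digits printed from compound 3 to compound 4 (within the scatter) is therefore small. For compound 4 the estimated value is 100 nM, with an expected range of 40 nM to 260 nM.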

Compound 4, half-maximal inhibitory concentration: 80 nM
Compound 4: middle estimate off by 1.3-fold (0.10 log units), on the high side; the range from low to high includes it.
By their numbers in this assay, from the lowest: compounds 4, 2, 3 and 1 (each within the scatter of the next).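

Replacing 2,3-dihydro-1,4-benzodioxin-6-yl with 4-fluoronaphthalen-1-yl gives, in this assay, a 1.3-fold lower number from compound 3 to compound 4 (0.10 log units; within the scatter). Within the data shown here, this is the first direct comparison at this aromatic carbon of the five-membered ring with 3 nitrogen, and it shows that the position can hold either group without a change beyond the scatter, even though one group has 2 hydrogen-bond acceptors and the other has none. No measurement here explains why the two groups give such similar results.

From the compounds shown here alone, both groups contain two six-membered rings, so it remains open whether a much smaller group, such as methyl, or a charged one, such as a carboxylic acid, would be accepted at this carbon. Going by these compounds, the part played by the fluorine also remains open, as only a plain naphthalen-1-yl group on this same core could isolate it.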